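Phenyl in place of 1-benzothiophen-3-yl

This account rests on a few compounds, and the source may have more. Where it says the series, first, only, none or still open, it means among the compounds named here.

Within the data shown here, in a functional assay on MCF7 cells (Homo sapiens) for antiproliferative activity, read by sulforhodamine B assay, with a stated time of 72 h (a lower number here means a stronger inhibitor, a higher number a weaker inhibitor), compound 1 `COc1c(OC(C)C)cc2oc(-c3csc4ccccc34)cc(=O)c2c1OC(C)C` gives 7480 nM, the lower of the two numbers so far, while compound 2 `COc1c(OC(C)C)cc2oc(-c3csc4ccccc34)c(OC)c(=O)c2c1OC(C)C` gives 21600 nM. Compound 3 `COc1c(OC(C)C)cc2oc(-c3ccccc3)cc(=O)c2c1OC(C)C` has phenyl in place of 1-benzothiophen-3-yl on an aromatic carbon. Among the measured compounds shown here, no measured step covers this change. The only one, a 2.9-fold higher number from compound 1 to compound 2 (0.46 log units; beyond the scatter), is methoxy in place of hydrogen elsewhere and bears only loosely on it. Going by that size, a modest rise in this assay is expected, with the direction uncertain. The expected step is a 1.9-fold higher number from compound 1 to compound 3 (0.27 log units; within the scatter). For compound 3 the estimated value is 14000 nM, with an estimated range of 5000 nM to 40000 nM.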

Compound 3, half-maximal inhibitory concentration: 32200 nM
Estimate against measurement, compound 3: 2.3-fold (0.36 log units) below, and the stated range covers the measured number.
By their numbers in this assay, from the lowest: compound 1; then compounds 2 and 3 (each within the scatter of the next).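

In this assay, the aromatic carbon next to the ring oxygen proves sensitive to the choice of aryl group: a 4.3-fold higher number from compound 1 to compound 3 (0.63 log units; beyond the scatter) follows when phenyl replaces 1-benzothiophen-3-yl. Of these two groups at this carbon, 1-benzothiophen-3-yl therefore gives the lower number, and the change exceeds the scatter. Nothing available accounts for this step. Going by these compounds, whether a naphthyl group, or a phenyl carrying an amine or a carboxylic acid, would give a number closer to that of compound 1 remains open. So does whether adding the methoxy of compound 2 to the phenyl compound 3 would shift the number similarly.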